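Rearranging a Side Chain on the Shared Core

The source may hold more compounds than are shown below. What is called first, only, known or untested is meant among the compounds shown, and "the series" means these compounds.

Compound 2 `Cn1ncc2c(=O)n(-c3ccccc3)c(SC(C)(C)c3ccccc3)nc21` sits second highest of the three numbers in an assay on isolated protein for inhibition of retinal dehydrogenase 2 (Homo sapiens) (on this read-out higher numbers stand for weaker inhibition and lower numbers for stronger inhibition), giving 2200 nM. Compound 3 `Cn1ncc2c(=O)n(-c3ccccc3)c(CNc3cccc(F)c3)nc21` gives 2300 nM in this assay, within the scatter of compound 2, while compound 1 `CC(Sc1nc2c(cnn2C)c(=O)n1-c1ccccc1)c1ccccn1` gives 63 nM. Among the measured compounds shown here, the only measured step, a 35-fold higher number from compound 1 to compound 2 (1.54 log units; beyond the scatter), is large and touches the same sulfur. Compound 4 `CCC(Sc1nc2c(cnn2C)c(=O)n1-c1ccccc1)c1ccccc1` differs from compound 2 by 1-phenylpropyl in place of 1-methyl-1-phenylethyl on a sulfur. For the measured compounds named here, no measured step isolates this rearrangement, and the step from compound 1 to compound 2 changes both the ring and the branching at once, so the guide is indirect. A moderate move toward the stronger number of compound 1 is expected, a 3.7-fold lower number from compound 2 to compound 4 (0.56 log units; beyond the scatter). Compound 4 is estimated at 600 nM in this assay, with a range from 150 nM to 2000 nM.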

Compound 4, half-maximal inhibitory concentration: 179 nM
Compound 4: middle estimate off by 3.4-fold (0.53 log units), on the high side, and the stated range covers the measured number.
By their numbers in this assay, from the lowest: compound 1; then compound 4; then compounds 2 and 3 (each within the scatter of the next).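

Keeping the same atoms and only rearranging the group on the sulfur gives a 12-fold lower number from compound 2 to compound 4 (1.09 log units; beyond the scatter) here, so the way this chain is joined counts at this position, not just its atoms. A pyridine ring is also not required for a low number: a 2.8-fold higher number from compound 1 to compound 4 (0.45 log units; beyond the scatter) is only a modest step, although it changes both the ring and the chain. No measurement available here explains either step. Still open, going by these compounds, is how a 1-(pyridin-2-yl)propyl group would compare on the same sulfur. A longer chain such as 1-phenylbutyl, or an amine on the chain, also remains untested in the compounds shown.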